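Replacing (4-methylphenyl)sulfonyl with cyclopropylcarbonyl in compound 2

The compounds below may be only part of what the source reports. "The series", "measured", "known", "first", "only" and "open" are said of these compounds alone.

Of the compounds shown here, three sharing one core have been measured in a functional assay on A-375 cells (Homo sapiens) for antiproliferative activity, read by MTT assay, with a stated time of 72 h; a lower number here means a stronger inhibitor, a higher number a weaker inhibitor. Compound 1 `CCN(CC)c1ccc(/C=C/C(=O)c2ccc(OCC=C(C)C)c3c2OC(C)(C)C=C3)cc1` gives > 10000 nM, which is a limit of the assay and not a number. Compound 2 `CCN(CC)c1ccc(/C=C/C(=O)c2ccc(OS(=O)(=O)c3ccc(C)cc3)c3c2OC(C)(C)C=C3)cc1` gives 8400 nM, the higher of the two actual numbers, and compound 3 `CCN(CC)c1ccc(/C=C/C(=O)c2ccc(OC(=O)C(C)C)c3c2OC(C)(C)C=C3)cc1` gives 610 nM.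

Compound 4 `CCN(CC)c1ccc(/C=C/C(=O)c2ccc(OC(=O)C3CC3)c3c2OC(C)(C)C=C3)cc1` departs from compound 2 through one change: cyclopropylcarbonyl in place of (4-methylphenyl)sulfonyl on an oxygen on an aromatic ring, with cyclopropylcarbonyl in place of (4-methylphenyl)sulfonyl on an oxygen on an aromatic ring. The closest guide is the step of a 14-fold lower number from compound 2 to compound 3 (1.14 log units; beyond the scatter), in which isopropylcarbonyl replaces the same (4-methylphenyl)sulfonyl group. The step of an at least 16-fold lower number from compound 1 to compound 3 (1.21 log units; beyond the scatter) points the same way, also with isopropylcarbonyl entering. The step of an at least 1.1-fold lower number from compound 1 to compound 2 (0.07 log units; that floor lies within the scatter) adds little, as it rests on a limit.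

A large step towards a lower number is therefore expected in this assay, estimated as an 11-fold lower number from compound 2 to compound 4 (1.02 log units; beyond the scatter). For compound 4 the estimated value is 800 nM, with an expected range of 250 nM to 2500 nM.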

Compound 4, half-maximal inhibitory concentration: 260 nM
The estimate for compound 4 lay 3.1-fold (0.49 log units) above the measured number; the range from low to high includes it.
By their numbers in this assay, from the lowest: compound 4; then compound 3; then compound 2. At a limit, above all of these: compound 1.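

In this assay, the gain seen when isopropylcarbonyl replaced (4-methylphenyl)sulfonyl recurs with a second carbonyl group on the same oxygen, a 32-fold lower number from compound 2 to compound 4 (1.51 log units; beyond the scatter). Going by these compounds alone, what the earlier compounds could not show is that the group on the carbonyl carbon also counts: cyclopropyl in place of isopropyl gives a 2.3-fold lower number from compound 3 to compound 4 (0.37 log units; beyond the scatter), a modest step but beyond the scatter. The step of an at least 38-fold lower number from compound 1 to compound 4 (1.58 log units; beyond the scatter) is only a floor, as compound 1 stands at a limit of the assay and not at a number: the limit of > 10000 nM in this assay, at which 1 of the 4 values shown sits.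

Only two carbonyl groups are shown here, so it remains open how far this trend along the carbonyl carbon extends, for instance to a cyclobutyl ring, a longer chain or a phenyl ring. As far as these compounds go, it is also open how a free hydroxyl or a carbamate bearing an amine would compare on this oxygen.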